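Swapping Nitro for Methoxy, Twice, in Cytotoxicity

The compounds below may be only part of what the source reports. "The series", "measured", "known", "first", "only" and "open" are said of these compounds alone.

Compound 1 `O=C(Nn1c(-c2cccc([N+](=O)[O-])c2)nc2c(-c3ccco3)n[nH]c2c1=O)c1cccnc1` and compound 2 `COc1cccc(-c2nc3c(-c4ccco4)n[nH]c3c(=O)n2NC(=O)c2cccnc2)c1` share one core. In a functional assay on SK-MEL-2 cells (Homo sapiens) for cytotoxicity, read by sulforhodamine B assay, with a stated time of 2 days, tested at 100 uM (on this read-out lower numbers stand for less inhibition and higher numbers for more inhibition at the one concentration tested (going by the name of the read-out)), compound 1 gives 19.2%, and compound 2 gives 34.1%. The change between them is methoxy in place of nitro on an aromatic carbon, and it produced a step of a number 14.9 percentage points higher from compound 1 to compound 2 (beyond the scatter). Compound 3 `CCCc1n[nH]c2c(=O)n(NC(=O)c3ccccc3)c(-c3cccc([N+](=O)[O-])c3)nc12` is built on a different core; how its core differs from that of compound 1 is not broken down here. In this assay compound 3 gives 22.9%, a number within the scatter of that of compound 1 and beyond the scatter relative to that of compound 2. Compound 4 `CCCc1n[nH]c2c(=O)n(NC(=O)c3ccccc3)c(-c3cccc(OC)c3)nc12` is the unmeasured partner of compound 3, differing from it by methoxy in place of nitro on an aromatic carbon, the same change seen once already. On the basis of that earlier step, the step expected for compound 4 is a number 13.1 percentage points higher from compound 3 to compound 4 (beyond the scatter). Compound 4 is therefore estimated at 36%, likely between 22% and 50%.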

Compound 4, a percentage reported as inhibition, at one concentration (the size of the read-out at that concentration, not a potency): 16.7%
Beside the measured number, compound 4's estimate is 19.3 percentage points above it; measured number outside the range, below it.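

On the core of compound 3, the change from 3-nitrophenyl to 3-methoxyphenyl gave a number 6.2 percentage points lower from compound 3 to compound 4 (within the scatter), so the rise seen on the core of compound 1 did not recur. Set side by side, the two steps differ: the same change on two cores in this assay, a number 14.9 percentage points higher (beyond the scatter) from compound 1 to compound 2 and a number 6.2 percentage points lower (within the scatter) from compound 3 to compound 4, 21.1 percentage points apart, beyond the scatter of two such steps. This shows that in this assay the step on one core cannot be carried to the other as a fixed amount, but it does not show which part of the difference between the cores is responsible, and two pairs establish no rule for the series.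

The compounds shown leave open how an amine or a carboxylic acid in the same place would compare with nitro and methoxy on either core. They also leave open whether a longer chain on the core of compound 3 would alter the step.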